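A few compounds are considered here, and "the series" means these few. Any claim that something is new, unique, unknown or untested is made for them only; others in the source may bear on it.

Series notes, shared core with a tert-butyl group and a variable substituent beside it.

Compound 1 `CCCCOc1nc(C(C)(C)C)ccc1CNC(=O)C(C)c1ccc(NS(C)(=O)=O)c(F)c1` carries a butoxy group and in an assay on cells for antagonist activity at transient receptor potential cation channel subfamily V member 1 (Homo sapiens), read by FLIPR and calcium flux, with a stated time of 6 min (on this read-out lower numbers stand for stronger inhibition and higher numbers for weaker inhibition), compound 1 gives 0.9 nM. Among the compounds with values here, compound 2 `CCOCCOc1nc(C(C)(C)C)ccc1CNC(=O)C(C)c1ccc(NS(C)(=O)=O)c(F)c1` carries 2-ethoxyethoxy and in this assay compound 2 gives 23.9 nM, the higher of the two numbers measured so far; the only step, a 27-fold higher number from compound 1 to compound 2 (1.42 log units; beyond the scatter), came with an ether oxygen entering the chain.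

Compound 3 `CCCCCCSc1nc(C(C)(C)C)ccc1CNC(=O)C(C)c1ccc(NS(C)(=O)=O)c(F)c1` is the next member: hexylsulfanyl in place of 2-ethoxyethoxy on an aromatic carbon. Within the data shown here, the chain of compound 3 holds no ether oxygen, so it resembles compound 1 more than compound 2 on this point, although the sulfur on the ring and the longer chain have no measured counterpart here. Among the measured compounds shown here, the one measured step bears on it only by analogy, and a gain roughly the size of a 27-fold higher number from compound 1 to compound 2 (1.42 log units; beyond the scatter) reversed is expected, with wide uncertainty.

For compound 3 the expected step is a 9.6-fold lower number from compound 2 to compound 3 (0.98 log units; beyond the scatter). Compound 3 is therefore estimated at 2.5 nM, between 0.5 nM and 15 nM.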

Compound 3, inhibition constant: 1.5 nM
For compound 3 the middle estimate is 1.7-fold (0.22 log units) above the measured one, and the stated range covers the measured number.
By their numbers in this assay, from the lowest: compounds 1 and 3 (each within the scatter of the next); then compound 2.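

In this assay, hexylsulfanyl in place of 2-ethoxyethoxy gives a 16-fold lower number from compound 2 to compound 3 (1.20 log units; beyond the scatter) at this position, on the aromatic carbon next to the ring nitrogen. Hexylsulfanyl in place of butoxy gives a 1.7-fold higher number from compound 1 to compound 3 (0.22 log units; within the scatter) and so leaves the number within the scatter, which shows that this position accepts a chain attached through sulfur as well as one attached through oxygen. Within the data shown here, of the three compounds, only compound 2, the one with an ether oxygen inside the chain, stands apart, and no compound here goes against that.

Butoxy and hexylsulfanyl differ in both the linking atom and the chain, so butylsulfanyl or hexyloxy would be needed to read each change alone. As far as these compounds go, how an amine or a carboxylic acid at the chain end would behave also remains open.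

No measurement at hand accounts for these differences.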